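The compounds below may be only part of what the source reports. "The series", "measured", "known", "first", "only" and "open" are said of these compounds alone.

In this small set of compounds, lipophilicity has been measured as a physicochemical assay for lipophilicity, at pH 7.4; a lower number here means a more polar compound, a higher number a more lipophilic compound. Repeat measurements of compound 1 `COC(c1cc(Cl)c2c(c1Cl)C(=O)N(Cc1c(C)cc(C)[nH]c1=O)CC2)C1CCOC1` give 3; 3; 3; 3 (4 entries). Compound 2 `COc1cc(C)[nH]c(=O)c1CN1CCc2c(Cl)cc(-c3c(C)noc3C)c(Cl)c2C1=O` gives 2.7, and the two values lie within the usual scatter of each other. For the measured compounds named here, compound 2 therefore stands level with the only other measured compound, and no measured pair differing in one place is available as a guide.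

The next compound, compound 3 `COc1cc(C)[nH]c(=O)c1CN1CCc2c(Cl)cc([C@H](O)C3COC3)c(Cl)c2C1=O`, is made from compound 2 by one change on an aromatic carbon, ortho to a chloro group: a group of 6 heavy atoms (4 carbon, 2 oxygen; one four-membered non-aromatic ring with 1 hetero atom) in place of a group of 7 heavy atoms (5 carbon, 1 nitrogen, 1 oxygen; one five-membered aromatic ring with 2 hetero atoms), on an aromatic carbon. The 3,5-dimethyl-1,2-oxazol-4-yl group leaves, and a group with a four-membered non-aromatic ring enters, bringing a defined stereocentre and a hydrogen-bond donor. Going by the values given here, with no measured step to draw on, the expectation rests on this structural change alone, starting from compound 2 at 2.7. A fall in this assay beyond the scatter is expected, towards the more polar end, and the estimated step is a number 0.90 log units lower from compound 2 to compound 3 (beyond the scatter). For compound 3 the expected value is 1.8, with an estimated range from 1.3 to 2.3.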

Compound 3, distribution coefficient: 1.4
For compound 3 the middle estimate is 0.40 log units above the measured one, within the range that was stated.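

For the compounds shown here, at this aromatic carbon, ortho to a chloro group, the measured change in this assay gives the first reading of a single-place exchange: replacing the 3,5-dimethyl-1,2-oxazol-4-yl group with the entering group with its four-membered non-aromatic ring gives a number 1.30 log units lower from compound 2 to compound 3 (beyond the scatter) and counts as a large step. Going by these compounds alone, compounds 1 and 2 differ in more than one place and could not show this, so this is the first sign that the value can move substantially through a change at this position alone. No measurement shown here accounts for the size of the step.

The step exchanges the ring, adds a hydrogen-bond donor and brings in a defined stereocentre all at once, so the compounds shown leave open which of these features matters, and whether the opposite stereocentre would read the same. They also leave open how a group such as an amine, a carboxylic acid or a longer chain at this same aromatic carbon would read in this assay on this core.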